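The source may report more compounds than this note shows. Statements on the series, on what has been measured and on what is new or still open speak of the compounds shown alone.

Of the compounds shown here, two on a shared core have been tested so far. Compound 1 `C=C1C(=O)O[C@H]2[C@H]1CC/C(COC(=O)Cn1cc(F)c(=O)[nH]c1=O)=C\CC[C@@]1(C)O[C@@H]21` gives > 20000 nM in a functional assay on Bel-7402 cells (Homo sapiens) for antiproliferative activity, read by MTT assay, with a stated time of 72 h (on this read-out higher numbers stand for weaker inhibition and lower numbers for stronger inhibition), which is a limit of the assay and not a number. Compound 2 `C=C1C(=O)O[C@H]2[C@H]1CC/C(COC(=O)CCC(=O)OCn1cc(F)c(=O)[nH]c1=O)=C\CC[C@@]1(C)O[C@@H]21`, which carries a different chain on the same core, gives > 20000 nM in this assay, again only a limit. Compound 1 therefore has no measured number, and the data set it neither ahead of compound 2 nor behind it. The whole record so far is the limit of > 20000 nM in this assay, at which 2 of the 2 values shown sit.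

Compound 3 `C=C1C(=O)O[C@H]2[C@H]1CC/C(COC(=O)Cn1cc(F)c(=O)n(Cc3ccc(Br)cc3)c1=O)=C\CC[C@@]1(C)O[C@@H]21` departs from compound 1 at a single place, with 4-bromobenzyl in place of hydrogen on an aromatic nitrogen. For the measured compounds named here, no measured step in this assay shows what such a change does, so any expectation here is loose. A moderate move toward stronger inhibition is expected, although compound 3 could well remain at the limit. The estimated size of that move is an at least 2.0-fold lower number from compound 1 to compound 3 (0.30 log units; that floor lies within the scatter). The estimate for compound 3 is 10000 nM, with an expected range from 2500 nM to 30000 nM.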

Compound 3, half-maximal inhibitory concentration: 2670 nM
Beside the measured number, compound 3's estimate is 3.7-fold (0.57 log units) above it; low and high end bracket the measured number.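

With 4-bromobenzyl in place of hydrogen on an aromatic nitrogen, this assay shows an at least 7.4-fold lower number from compound 1 to compound 3 (0.87 log units; beyond the scatter), so this nitrogen is a place on the shared core where a single change moves the read-out beyond the scatter, and it lifts compound 3 off the limit that the other compounds shown sit at. Compound 1 gives > 20000 nM, which is a limit of the assay and not a number. The step is therefore a floor and its full size cannot be told, while compound 3 alone carries a measured number against a record otherwise made up of limits: the limit of > 20000 nM in this assay, at which 2 of the 3 values shown sit.

On these data alone, whether the change depends on the bromine, on the aromatic ring or on the mere presence of a carbon group at this nitrogen remains open, since a plain benzyl, a 4-chlorobenzyl or a simple methyl there would separate these parts. It also remains open whether 4-bromobenzyl would have a similar effect on the longer chain of compound 2, where only the hydrogen form is shown.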